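A few compounds are considered here, and "the series" means these few. Any claim that something is new, unique, unknown or untested is made for them only; others in the source may bear on it.

The measured compounds and their values:

Compound 1, `Nc1ncnc2c1ncn2CC(O)C(=O)OCCO` — in a functional assay on HeLa cells (Homo sapiens) for cytotoxicity (a lower number here means that less compound is tolerated, a higher number that more compound is tolerated), compound 1 gives > 400 ug/mL, a limit of the assay.
Compound 2, `CCCCCCCCOC(=O)C(O)Cn1cnc2c(N)ncnc21` — in this assay compound 2 gives 100 ug/mL.
Compound 3, `CC(C)OC(=O)C(O)Cn1cnc2c(N)ncnc21` — in this assay compound 3 gives > 400 ug/mL, a limit of the assay.

Compound 3 therefore stands at the upper edge of what this assay reports, sharing the limit of > 400 ug/mL in this assay, at which 2 of the 3 values shown sit, with compound 1, and no number for it is known. Compound 4, `CCCCCOC(=O)C(O)Cn1cnc2c(N)ncnc21`, differs from compound 3 at the ester oxygen: pentyl in place of isopropyl on an oxygen next to a carbonyl group.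

Among the measured compounds shown here, two measured steps touch this change. The step of an at least 4.0-fold higher number from compound 2 to compound 3 (0.60 log units; beyond the scatter) shows that shortening the ester chain from octyl to isopropyl moved the value up to the limit. The step of an at least 4.0-fold lower number from compound 1 to compound 2 (0.60 log units; beyond the scatter) shows that lengthening the chain from the hydroxyethyl ester to octyl brought the value down to a readable number. Pentyl lies between isopropyl and octyl in chain length, so a lower number than at the limit is expected for compound 4, of size an at least 1.6-fold lower number from compound 3 to compound 4 (0.20 log units; that floor lies within the scatter), with a fair chance that compound 4 still sits at the limit. The estimate for compound 4 in this assay is 250 ug/mL, within 100 ug/mL to 400 ug/mL.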

Compound 4, minimum cytotoxic concentration: > 400 ug/mL
Compound 4: only a limit was reported; the forecaster's own chance of this, stated with the estimate: 40%; middle value at least 1.6-fold (0.20 log units) away from the limit.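

In this assay compound 4 gives > 400 ug/mL, which is a limit of the assay, so pentyl on this ester oxygen stays at the limit just as isopropyl does. Set against the octyl ester, the change reads as an at least 4.0-fold higher number from compound 2 to compound 4 (0.60 log units; beyond the scatter), so among the esters shown the value comes off the limit only with octyl, not yet with pentyl. The steps from compound 1 and compound 3 to compound 4 cannot be read, both ends being limits, and the limit now holds most of the compounds: the limit of > 400 ug/mL in this assay, at which 3 of the 4 values shown sit.

As far as these compounds go, at which chain length past pentyl the value first becomes readable stays open, as do the actual numbers of compound 1, compound 3 and compound 4. Hexyl and heptyl esters would narrow that point, and a longer chain such as decyl would show whether the value keeps falling past octyl.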